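The source may hold more compounds than are shown below. What is called first, only, known or untested is meant among the compounds shown, and "the series" means these compounds.

Values in an ADME assay on microsomes from liver (Homo sapiens) for metabolic stability; a higher number here means that the compound lasts longer, a lower number that the compound disappears faster:

- Compound 1 `CCn1ncc2c(F)cc(-c3ccc(C(CC)(CC)c4nnc[nH]4)c(=O)[nH]3)cc21`: 2.7 h
- Compound 2 `CCn1ncc2c(F)cc(-c3ccc(C(CC)(CC)c4nnc(C)[nH]4)c(=O)[nH]3)cc21`: > 3 h (a limit)
- Compound 3 `CC(C)C(Cc1noc(=O)[nH]1)c1ccc(-c2ccc3cccc(F)c3c2)[nH]c1=O`: > 3 h (a limit)

Compound 2 gives > 3 h, which is a limit of the assay and not a number. It stands at the limit of > 3 h in this assay, at which 2 of the 3 values shown sit.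

The next compound to be read is compound 4 `CCn1ncc2c(F)cc(-c3ccc(C(CC)(CC)c4ncn(C)n4)c(=O)[nH]3)cc21`, which has the same atoms as compound 2, joined differently: 1-methyl-1H-1,2,4-triazol-3-yl in place of 5-methyl-4H-1,2,4-triazol-3-yl on a saturated chain carbon bound to an aromatic carbon and two saturated chain carbons. Here 1-methyl-1H-1,2,4-triazol-3-yl stands in place of 5-methyl-4H-1,2,4-triazol-3-yl on a saturated chain carbon bound to an aromatic carbon and two saturated chain carbons.

For the measured compounds named here, only one measured step comes near this change: an at least 1.1-fold higher number from compound 1 to compound 2 (0.04 log units; that floor lies within the scatter). That step puts methyl in place of hydrogen on an aromatic carbon, so it bears only loosely on the present exchange. It gives no ground to expect a change beyond the scatter in this assay, in either direction.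

The expected step is an at least 1.2-fold lower number from compound 2 to compound 4 (0.07 log units; that floor lies within the scatter). Compound 4 is estimated at 2.5 h, with an expected range of 1.2 h to 3.5 h.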

Compound 4, half-life: > 3 h
Compound 4 ended at the assay's limit; the forecaster's own chance of this, stated with the estimate: 40%; at least 1.2-fold (0.07 log units) between middle value and limit.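

In this assay compound 4 gives > 3 h, which is a limit of the assay and not a number. At this place, 1-methyl-1H-1,2,4-triazol-3-yl, with no hydrogen-bond donor, reaches the same limit as 5-methyl-4H-1,2,4-triazol-3-yl, with one donor, so the step between these two compounds cannot be read. Against 4H-1,2,4-triazol-3-yl, the exchange gives an at least 1.1-fold higher number from compound 1 to compound 4 (0.04 log units; that floor lies within the scatter), and the read-out for this series is capped: the limit of > 3 h in this assay, at which 3 of the 4 values shown sit.

Going by these compounds, how far compound 2 and compound 4 lie apart remains open, and so does any ranking among the compounds at the limit. Also open, on these data alone, is whether a carboxylic acid or an amine in place of 1-methyl-1H-1,2,4-triazol-3-yl would stay at this limit.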